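Acylating the free amine of compound 2 once more

A few compounds are considered here, and "the series" means these few. Any claim that something is new, unique, unknown or untested is made for them only; others in the source may bear on it.

Measured so far:
Compound 1, `COc1ccc(Cl)cc1C(=O)Nc1nc(-c2ccccc2)nc2c1nnn2Cc1ccccc1`: in an assay (strain Wistar) for displacement of a labelled ligand from adenosine receptor A1 (Rattus norvegicus), read by scintillation counting (a lower number here means a stronger inhibitor, a higher number a weaker inhibitor), compound 1 gives 7150 nM.
Compound 2, `Nc1nc(-c2ccccc2)nc2c1nnn2Cc1ccccc1`: in this assay compound 2 gives 5.6 nM.

Among these two numbers compound 2 stands lowest; its only neighbour is compound 1, and the single step between them, a 1300-fold lower number from compound 1 to compound 2 (3.11 log units; beyond the scatter), came with hydrogen in place of a bulky acyl group on the ring nitrogen. The new compound 3, `O=C(Nc1nc(-c2ccccc2)nc2c1nnn2Cc1ccccc1)C1CC1`, goes the other way: cyclopropylcarbonyl in place of hydrogen on a nitrogen on an aromatic ring. The step from compound 1 to compound 2 is the only one that bears on this, and it was very large; read in reverse it says that placing an acyl group on that nitrogen raised the number sharply. For the measured compounds named here, the group entering here is much smaller than the one that left in compound 1, so a rise is expected in this assay, though probably a smaller one. Compound 3 is estimated at 300 nM, with a range from 40 nM to 3000 nM, which means an expected step of a 54-fold higher number from compound 2 to compound 3 (1.73 log units; beyond the scatter).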

Compound 3, inhibition constant: 7.5 nM
Compound 3: middle estimate off by 40-fold (1.60 log units), on the high side, and the stated range ends above it.
By their numbers in this assay, from the lowest: compounds 2 and 3 (each within the scatter of the next); then compound 1.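

In this assay, an acyl group on this nitrogen does not by itself raise the number: with cyclopropylcarbonyl in place of hydrogen, the change is a 1.3-fold higher number from compound 2 to compound 3 (0.13 log units; within the scatter). The very large rise seen earlier thus goes with what sits on the carbonyl carbon rather than with the amide as such, since keeping the amide and having cyclopropyl in place of 5-chloro-2-methoxyphenyl gives a 950-fold lower number from compound 1 to compound 3 (2.98 log units; beyond the scatter). Why these two groups on the carbonyl carbon behave so differently is something no measurement here can explain.

The compounds shown leave open where, between cyclopropyl and 5-chloro-2-methoxyphenyl, the number starts to climb: a plain phenyl, a small methyl or a longer chain such as butyl on the carbonyl carbon could stay with compound 3 or move towards compound 1. They also leave open whether the chloro or the methoxy part of the group in compound 1 matters more, or whether the aromatic ring alone is enough to produce the rise.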